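The source may hold more compounds than are shown below. What is called first, only, known or untested is meant among the compounds shown, and "the series" means these compounds.

Working notes on the series, read in a toxicity assay on J774.A1 cells (Mus musculus) for cytotoxicity, read by SYBR Green assay, with a stated time of 1 h; a lower number here means that less compound is needed, a higher number that more compound is needed for the effect. Compound 1 (`CN(C)c1ccc2cc(-c3ccccc3F)c(N)nc2c1`) gives 1600 nM, compound 2 (`CN(C)c1ccc2cc(-c3ccccc3Cl)c(N)nc2c1`) gives 2400 nM, and compound 3 (`Cc1ccccc1-c1cc2ccc(N(C)C)cc2nc1N`) gives 6800 nM. Compound 3 therefore has the highest number of the three and lies beyond the scatter from both others.

The next compound is compound 4 (`COc1ccccc1-c1cc2ccc(N(C)C)cc2nc1N`), with methoxy in place of methyl on an aromatic carbon, ortho to a large group: methoxy in place of methyl on an aromatic carbon.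

Three measured single-group exchanges bear on this change. The exchange from fluoro to chloro is a 1.5-fold higher number from compound 1 to compound 2 (0.18 log units; within the scatter). The exchange from fluoro to methyl is a 4.3-fold higher number from compound 1 to compound 3 (0.63 log units; beyond the scatter), and the exchange from chloro to methyl is a 2.8-fold higher number from compound 2 to compound 3 (0.45 log units; beyond the scatter). Within the data shown here, no measured compound carries methoxy, so these steps give only a rough size, and none of them tests this exchange directly.

The two steps that involve methyl are modest, so a modest step at most is expected in this assay. With compound 3 at the top of the range at 6800 nM, a move to a lower number is judged likelier than a further rise, though it may not clear the scatter. The expected change is a 1.7-fold lower number from compound 3 to compound 4 (0.23 log units; within the scatter). For compound 4 the estimated value is 4000 nM, with an expected range of 1600 nM to 10000 nM.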

Compound 4, half-maximal effective concentration: 4800 nM
Estimate against measurement, compound 4: 1.2-fold (0.08 log units) below; the measured number falls inside the stated range.
By their numbers in this assay, from the lowest: compounds 1, 2, 4 and 3 (each within the scatter of the next, the first and the last beyond it).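

In this assay, exchanging methyl for methoxy, which adds one oxygen and a hydrogen-bond acceptor on an aromatic carbon ortho to a large group, gives a 1.4-fold lower number from compound 3 to compound 4 (0.15 log units; within the scatter) and so produces no readable shift at this position. Methoxy keeps the separation from fluoro that methyl showed, with a 3.0-fold higher number from compound 1 to compound 4 (0.48 log units; beyond the scatter) as a modest step, but it does not keep the separation from chloro, with a 2.0-fold higher number from compound 2 to compound 4 (0.30 log units; within the scatter) set against a 2.8-fold higher number from compound 2 to compound 3 (0.45 log units; beyond the scatter) for methyl. No measurement available here accounts for this difference between methoxy and methyl.

The compounds shown leave open whether a group of another kind at this place, such as an amine, a carboxylic acid or a longer chain, would move the number in this assay beyond the scatter from the values seen so far. They also leave open whether the same exchanges would give steps of similar size with a change elsewhere on the shared core, since all four compounds differ at this one place only.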